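A few compounds are considered here, and "the series" means these few. Any claim that something is new, unique, unknown or untested is made for them only; others in the source may bear on it.

Compound 1, `COc1cccc(NC(=O)c2nnn(Cc3cc(C)on3)c2N)c1`: in a toxicity assay on Vero cells (Chlorocebus sabaeus) for inhibition (a lower number here means that less compound is needed, a higher number that more compound is needed for the effect), compound 1 reaches only a limit of the assay, > 50100 nM.
Compound 2, `COc1cccc(NC(=O)c2nnn(Cc3ccc(-n4cccn4)cc3)c2N)c1`: compound 2 likewise reaches only the limit > 50100 nM.
Compound 3, `COc1cccc(NC(=O)c2nnn(Cc3ccc(C(C)C)cc3)c2N)c1`: compound 3 also stops at the limit > 50100 nM.

Compound 3 therefore stands where all three measured compounds stand, at the limit of > 50100 nM in this assay, at which 3 of the 3 values shown sit. The move to compound 4, `COc1cccc(NC(=O)c2nnn(Cc3ccc(C#N)cc3)c2N)c1`, is cyano in place of isopropyl on an aromatic carbon. The two measured steps that touch compound 3, a step that the two limits leave unreadable from compound 1 to compound 3 and a step that the two limits leave unreadable from compound 2 to compound 3, cannot be sized, so no readable change is available to build on. The expected step is a step that the limit leaves unreadable from compound 3 to compound 4, none beyond the scatter. Compound 4 is estimated at 100000 nM, with a range from 30000 nM to 300000 nM, and will most probably be reported again only as a limit.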

Compound 4, half-maximal effective concentration in the Vero assay: > 50100 nM
Compound 4: no number, only a limit; the forecaster's own chance of this, stated with the estimate: 85%; the middle value does not contradict the limit.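

In the Vero assay no step can be read from compound 1, compound 2 or compound 3 to compound 4, since all four stop at the same limit: the limit of > 50100 nM in the Vero assay, at which 4 of the 4 values shown sit.

In a physicochemical assay for solubility, read by nephelometry, at pH 7.4 (a higher number here means a more soluble compound, a lower number a less soluble compound), compound 3 gives 14000 nM and compound 4 gives 216000 nM.

The compounds shown leave open what concentration of any of them reaches the effect in the Vero assay.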